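The compounds below may be only part of what the source reports. "The series", "measured", "known", "first", "only" and "open" are said of these compounds alone.

In a functional assay on HCT-116 cells (Homo sapiens) for antiproliferative activity, read by CCK-8 assay, with a stated time of 72 h (on this read-out lower numbers stand for stronger inhibition and higher numbers for weaker inhibition), compound 1 `COc1ccc(SCc2ccc(C(=O)Nc3ccccc3N)cc2)cc1` gives 1640 nM and compound 2 `Cc1ccc(SCc2ccc(C(=O)Nc3ccccc3N)cc2)cc1` gives 2630 nM so these two values lie within the usual scatter of each other. Going by the values given here, compound 3 `Cc1cc(C)cc(SCc2ccc(C(=O)Nc3ccccc3N)cc2)c1` differs from compound 2 by having 3,5-dimethylphenyl in place of 4-methylphenyl on a sulfur as its one change. Among the compounds with values here, the only measured guide is a 1.6-fold higher number from compound 1 to compound 2 (0.21 log units; within the scatter) with methyl in place of methoxy on an aromatic carbon, so in this assay no step beyond the scatter is expected. The estimated step is a 1.1-fold higher number from compound 2 to compound 3 (0.03 log units; within the scatter) in size. For compound 3 the estimated value is 2800 nM (expected range 1100 nM to 7000 nM).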

Compound 3, half-maximal inhibitory concentration: 2490 nM
Compound 3: the middle estimate sits 1.1-fold (0.05 log units) above what was measured, and the stated range covers the measured number.
By their numbers in this assay, from the lowest: compounds 1, 3 and 2 (each within the scatter of the next).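

In this assay there is a 1.1-fold lower number from compound 2 to compound 3 (0.02 log units; within the scatter) for 3,5-dimethylphenyl in place of 4-methylphenyl on a sulfur, and a 1.5-fold higher number from compound 1 to compound 3 (0.18 log units; within the scatter) for 3,5-dimethylphenyl in place of 4-methoxyphenyl. So a second methyl and a different placement on this ring, not just a swap of one group, still leave all three compounds within the scatter of each other. No measurement shown gives a reason for this. Still open, from the compounds shown here alone, is whether an amine or a carboxylic acid on this ring, or a longer chain in place of the ring on the sulfur, would give a step beyond the scatter.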